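This account rests on a few compounds, and the source may have more. Where it says the series, first, only, none or still open, it means among the compounds named here.

Measured compounds and their values in an assay on isolated protein for inhibition of Alpha glucosidase (Homo sapiens), with stated times of 5 min and 15 min, tested at 50 uM; on this read-out lower numbers stand for less inhibition and higher numbers for more inhibition at the one concentration tested (going by the name of the read-out):
- Compound 1 `O=C1/C(=C/c2ccccc2)CCC/C1=C\c1ccc(Cl)cc1` gives 27.6% in this assay.
- Compound 2 `O=C(C1=C(O)/C(=C/c2ccc(O)c(O)c2)CCC1)c1ccccc1` gives 55.9% in this assay.
- Compound 3 `O=C1/C(=C/c2ccccc2)CCC/C1=C\c1ccc(F)c(F)c1` gives 37.8% in this assay.

Among these three, compound 1 stands lowest. Its nearest neighbour on the numbers is compound 3, which lies higher by a margin beyond the usual scatter, and compound 2 lies further still above it, also beyond the scatter. Among the measured compounds shown here, no two of the measured compounds differ in a single place, so no measured step is available to lean on.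

Compound 4 `COc1ccc(/C=C2\CCC/C(=C\c3ccccc3)C2=O)cc1` is the one still to be measured. Compared with compound 1 it differs as follows: methoxy in place of chloro on an aromatic carbon. For the measured compounds named here, since no measured pair shows what such an exchange does on this read-out, the expectation for compound 4 rests only on the values of compound 1 and compound 3, which sit close together at the low end of the set. The step of a number 4.4 percentage points higher from compound 1 to compound 4 (within the scatter) is expected to be small and upward at most, not clearly beyond the scatter. Compound 4 is accordingly estimated at 32%, with a range from 18% to 46%.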

Compound 4, a percentage reported as inhibition, at one concentration (the size of the read-out at that concentration, not a potency): 31.4%
For compound 4 the middle estimate is 0.6 percentage points above the measured one; low and high end bracket the measured number.
By their numbers in this assay, from the lowest: compounds 1, 4 and 3 (each within the scatter of the next, the first and the last beyond it); then compound 2.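

In this assay, among the compounds shown here, the exchange of chloro for methoxy on an aromatic carbon, para to a large group, gives a number 3.8 percentage points higher from compound 1 to compound 4 (within the scatter) and provides the first reading of a change at a single place in this set. At this position, two heavy atoms and one hydrogen-bond acceptor can therefore enter where one chlorine leaves without a change that can be told from the scatter, so this read-out at its one tested concentration does not separate the two compounds. No measurement shown accounts for this result.

The compounds shown leave open whether a group of a different kind at this same place, such as an amine or a carboxylic acid, would move the read-out beyond the scatter. They also leave open whether the same exchange would read alike on the other aromatic ring of the core, and whether compound 1 and compound 4 would still read alike at other concentrations.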